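Chloro in Place of Fluoro: Expecting Compound 4

This account rests on a few compounds, and the source may have more. Where it says the series, first, only, none or still open, it means among the compounds named here.

Compound 1 `Nc1sc2c(c1-c1nc3ccccc3s1)CCCC2`: 253 ug/mL
Compound 2 `Fc1ccc(/C=N/c2sc3c(c2-c2nc4ccccc4s2)CCCC3)cc1`: 230 ug/mL
Compound 3 `Fc1ccccc1/C=N/c1sc2c(c1-c1nc3ccccc3s1)CCCC2`: 319 ug/mL

Three compounds sharing one core have been run in an ADME assay on cells (Rhabdomyosarcoma cell, Homo sapiens) for cytotoxicity, read by MTT assay, with a stated time of 72 h; on this read-out lower numbers stand for higher toxicity in this test and higher numbers for lower toxicity in this test. Compound 1 gives 253 ug/mL, compound 2 gives 230 ug/mL and compound 3 gives 319 ug/mL. Compound 3 has the highest of the three numbers, but the step of a 1.3-fold higher number from compound 1 to compound 3 (0.10 log units; within the scatter) and the step of a 1.4-fold higher number from compound 2 to compound 3 (0.14 log units; within the scatter) are both within the scatter, so nothing separates it from the others. The step of a 1.1-fold lower number from compound 1 to compound 2 (0.04 log units; within the scatter) is likewise within the scatter.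

Compound 4 `Clc1ccccc1/C=N/c1sc2c(c1-c1nc3ccccc3s1)CCCC2` differs from compound 3 by chloro in place of fluoro on an aromatic carbon. The step that bears most closely on this change is the one within the fluorophenyl ring, a 1.4-fold higher number from compound 2 to compound 3 (0.14 log units; within the scatter), where moving the same halogen to another position of the ring left the number within the scatter. The larger steps from the amine, a 1.1-fold lower number from compound 1 to compound 2 (0.04 log units; within the scatter) and a 1.3-fold higher number from compound 1 to compound 3 (0.10 log units; within the scatter), also stayed within the scatter. For the measured compounds named here, nothing among the measured compounds points to a step beyond the scatter for a halogen swap, and in this assay compound 4 is therefore expected to show a 1.1-fold lower number from compound 3 to compound 4 (0.04 log units; within the scatter). Compound 4 is estimated at 290 ug/mL, within the range 170 ug/mL to 500 ug/mL.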

Compound 4, half-maximal cytotoxic concentration: 332 ug/mL
Beside the measured number, compound 4's estimate is 1.1-fold (0.06 log units) below it, and the stated range covers the measured number.
By their numbers in this assay, from the lowest: compounds 2, 1, 3 and 4 (each within the scatter of the next).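

In this assay, the earlier compounds had shown only that moving fluoro around the ring left the number within the scatter; this result adds that exchanging the halogen itself at this place, on an aromatic carbon ortho to a large group, does the same (a 1.0-fold higher number from compound 3 to compound 4 (0.02 log units; within the scatter)). The 2-chlorophenyl group also stays within the scatter of the 4-fluorophenyl group (a 1.4-fold higher number from compound 2 to compound 4 (0.16 log units; within the scatter)) and of the amine of compound 1 (a 1.3-fold higher number from compound 1 to compound 4 (0.12 log units; within the scatter)), so the new step separates none of the four compounds in this test. No measurement given here bears on why the number stays within the scatter when chloro replaces fluoro.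

The compounds shown leave open whether a group of another kind at this place, such as methoxy, a carboxylic acid or a dimethylamino group, would carry the number beyond the scatter. They also leave open whether bromo or a trifluoromethyl group would behave as fluoro and chloro do here, and whether any such result would hold on a different core.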